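The source may hold more compounds than are shown below. What is called first, only, known or untested is meant among the compounds shown, and "the series" means these compounds.

Compound 1 `CO[C@H]1CC[C@@H](Nc2cc(NCc3cnccc3C(F)(F)F)ncc2C#N)CC1` gives 58 nM in an assay on isolated protein for inhibition of protein kinase C theta type (Homo sapiens), read by TR-FRET, with a stated time of 2 h (a lower number here means a stronger inhibitor, a higher number a weaker inhibitor), the same value as compound 2 `N#Cc1cnc(NCc2cnccc2C(F)(F)F)cc1NC[C@H]1CC[C@@H](O)CC1`, which gives 58 nM; together they give the lowest of the three numbers, and compound 3 `CO[C@H]1CC[C@@H](CNc2cc(NCc3cnccc3C(F)(F)F)ncc2C#N)CC1` gives 70 nM. The step of no change at the digits printed from compound 1 to compound 2 (within the scatter) and the step of a 1.2-fold higher number from compound 1 to compound 3 (0.08 log units; within the scatter) both swap the group on the saturated ring without any change beyond the scatter, and the step of a 1.2-fold higher number from compound 2 to compound 3 (0.08 log units; within the scatter) behaves the same. Compound 4 `CN(C)C(=O)[C@H]1CC[C@@H](Nc2cc(NCc3cnccc3C(F)(F)F)ncc2C#N)CC1` carries dimethylcarbamoyl in place of methoxy on a saturated ring carbon. Since every change on this ring so far, including no change at the digits printed from compound 1 to compound 2 (within the scatter), stayed within the scatter, the expected step of a 1.3-fold higher number from compound 1 to compound 4 (0.11 log units; within the scatter) is small, with no clear direction. Compound 4 is therefore expected to give 75 nM, in a range from 30 nM to 190 nM.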

Compound 4, half-maximal inhibitory concentration: 38 nM
Compound 4: middle estimate off by 2.0-fold (0.30 log units), on the high side; low and high end bracket the measured number.
By their numbers in this assay, from the lowest: compounds 4, 1, 2 and 3 (each within the scatter of the next).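

Putting dimethylcarbamoyl in place of methoxy on this saturated ring carbon gives a 1.5-fold lower number from compound 1 to compound 4 (0.18 log units; within the scatter) in this assay. The entering group has 5 heavy atoms against 2 for methoxy, so this position can carry a clearly larger group, including a carbonyl, and the number stays within the scatter of compound 1. No measurement here explains this result. Still open, on these data alone, is whether an amine or a carboxylic acid on this ring carbon would stay in the same range, and whether a longer chain on the amide nitrogen would.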